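Urea in Place of Benzyl on the Ring Amine

A few compounds are considered here, and "the series" means these few. Any claim that something is new, unique, unknown or untested is made for them only; others in the source may bear on it.

Measured so far:
compound 1, `NC(=O)c1c(NC(=O)c2ccc(C(F)(F)F)cc2)sc2c1CCN(Cc1c(Cl)cccc1Cl)C2` — > 50000 nM
compound 2, `NC(=O)c1c(NC(=O)c2ccccc2F)sc2c1CCN(Cc1cccc(Cl)c1)C2` — 49500 nM

In a functional assay on HeLa cells (Homo sapiens) for antiproliferative activity, with a stated time of 24 h (a higher number here means a weaker inhibitor, a lower number a stronger inhibitor), compound 1 reaches only > 50000 nM, which is a limit of the assay and not a number (the limit of > 50000 nM in this assay, at which 1 of the 2 values shown sits). Compound 2 gives 49500 nM, the only number shown, so it stands alone as a measured point. Compound 3, `NC(=O)c1c(NC(=O)c2ccccc2F)sc2c1CCN(C(=O)Nc1ccccc1Cl)C2`, carries (2-chlorophenyl)carbamoyl in place of 3-chlorobenzyl on an amine nitrogen in a ring. Among the measured compounds shown here, no measured step exists between compounds. With compound 2 already very weak, the change is expected to bring no step beyond the scatter, and the expected step from compound 2 to compound 3 is a 1.1-fold lower number from compound 2 to compound 3 (0.04 log units; within the scatter). Compound 3 is expected at 45000 nM, within 12000 nM to 50000 nM.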

Compound 3, half-maximal inhibitory concentration: > 50000 nM
Compound 3: no number, only a limit; the forecaster's own chance of this, stated with the estimate: 45%; at least 1.1-fold (0.04 log units) between middle value and limit.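

In this assay compound 3 gives > 50000 nM, which is a limit of the assay and not a number. Putting (2-chlorophenyl)carbamoyl in place of 3-chlorobenzyl on an amine nitrogen in a ring gives a number no lower from compound 2 to compound 3 (the limit leaves the size open), so this urea brings no gain in strength at this position. Most of the values now sit at one end of the range, which makes any loss impossible to size: the limit of > 50000 nM in this assay, at which 2 of the 3 values shown sit.

As far as these compounds go, whether a methyl or an acetyl group on this nitrogen would give a readable number stays open. So does the effect of leaving the ring amine with just its hydrogen.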